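A few compounds are considered here, and "the series" means these few. Any claim that something is new, unique, unknown or untested is made for them only; others in the source may bear on it.

In an assay for inhibition of gamma-butyrobetaine dioxygenase (Homo sapiens), read by HPLC, with stated times of 15 min and 30 min (on this read-out higher numbers stand for weaker inhibition and lower numbers for stronger inhibition), three measured compounds share one core and differ only at a single saturated chain carbon bound to an amine nitrogen. Compound 1 `C[N+](C)(CCCC(=O)[O-])CC1CC1` carries a cyclopropyl there, and in this assay compound 1 reaches only the limit > 1000000 nM. Compound 2 `CCC[N+](C)(C)CCCC(=O)[O-]` carries an ethyl there, and in this assay compound 2 likewise stops at the limit > 1000000 nM. Compound 3 `C[N+](C)(CBr)CCCC(=O)[O-]` carries a bromo there, and in this assay compound 3 again gives only the limit > 1000000 nM. Because all three sit at the limit of > 1000000 nM in this assay, at which 3 of the 3 values shown sit, none of the steps between them can be read: a step that the two limits leave unreadable from compound 1 to compound 2, a step that the two limits leave unreadable from compound 1 to compound 3 and a step that the two limits leave unreadable from compound 2 to compound 3. Compound 3 therefore stands nowhere in particular, one of three equally unresolved values. Compound 4 `C=C[N+](C)(C)CCCC(=O)[O-]` differs from compound 3 by vinyl in place of bromomethyl on an amine nitrogen. Going by the values given here, no measured step bears readably on this change. Since every compound shown rests at the limit of > 1000000 nM in this assay, at which 3 of the 3 values shown sit, compound 4 is expected to behave alike, with an expected step that the limit leaves unreadable from compound 3 to compound 4. Compound 4 is estimated at 2000000 nM, within a range from 300000 nM to 20000000 nM, most likely again reported only as a limit.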

Compound 4, half-maximal inhibitory concentration: 127000 nM
Compound 4: the middle estimate sits 16-fold (1.20 log units) above what was measured, and the stated range ends above it.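

In this assay, going by these compounds alone, vinyl on the amine nitrogen gives the only value in this set that is a number rather than a limit, so the assay can respond to a change in this group. Set against each of the other three groups, the change reads as an at least 7.8-fold lower number from compound 3 to compound 4 (0.89 log units; beyond the scatter), an at least 7.8-fold lower number from compound 2 to compound 4 (0.89 log units; beyond the scatter) and an at least 7.8-fold lower number from compound 1 to compound 4 (0.89 log units; beyond the scatter), and each size is only a minimum, since each starting compound carries a limit. Bromomethyl, propyl and cyclopropylmethyl remain unresolved, and the steps among them still cannot be read: the limit of > 1000000 nM in this assay, at which 3 of the 4 values shown sit.

Going by these compounds, with one numeric value, the part played by the double bond of vinyl stays open. An ethyl group on the same nitrogen would test this directly, while allyl and ethynyl groups would show how far the change can be extended.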